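The source may hold more compounds than are shown below. What is called first, only, known or untested is meant among the compounds shown, and "the series" means these compounds.

Three compounds have been measured in a functional assay on MCF7 cells (Homo sapiens) for antiproliferative activity, read by MTT assay, with a stated time of 48 h; on this read-out lower numbers stand for stronger inhibition and higher numbers for weaker inhibition:

Compound 1 `COc1ccc(C(=O)/C=C/c2cccc(Br)c2Oc2c([N+](=O)[O-])cc(C(F)(F)F)cc2[N+](=O)[O-])cc1` gives 2.32 ug/mL.
Compound 2 `COc1ccc(C(=O)/C=C/c2cccc(Cl)c2Oc2c([N+](=O)[O-])cc(C(F)(F)F)cc2[N+](=O)[O-])cc1` gives 1.83 ug/mL.
Compound 3 `O=C(/C=C/c1cc(Br)cc(Br)c1Oc1c([N+](=O)[O-])cc(C(F)(F)F)cc1[N+](=O)[O-])c1ccc(Cl)cc1` gives 6.76 ug/mL.

Compound 1 and compound 2 share a core and differ in one place: bromo in place of chloro on an aromatic carbon. That change gave a 1.3-fold higher number from compound 2 to compound 1 (0.10 log units; within the scatter), so the two numbers are as good as the same. Compound 3 stands apart: its number is higher than that of compound 1 and that of compound 2, and both steps to it lie beyond the scatter. The difference between the core of compound 3 and the core of compound 2 is not broken down here.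

Compound 4 `O=C(/C=C/c1cc(Br)cc(Br)c1Oc1c([N+](=O)[O-])cc(C(F)(F)F)cc1[N+](=O)[O-])c1ccc(Br)cc1` has not been measured. It differs from compound 3 in one place: bromo in place of chloro on an aromatic carbon. For the measured compounds named here, this is the same kind of change as the one between compound 2 and compound 1, but not the same change: there the halogen sits ortho to a large group and meta to a 2-((4-methoxyphenyl)carbonyl)ethenyl group, here it sits para to a large group. Going by the values given here, only one step of this kind has been measured, and nothing among the three measured compounds points to a larger step when chlorine is exchanged for bromine. Because the step of a 1.3-fold higher number from compound 2 to compound 1 (0.10 log units; within the scatter) stayed within the scatter, a step of similar size is expected here: a 1.0-fold higher number from compound 3 to compound 4 (0.02 log units; within the scatter). For compound 4 the expected value in this assay is 7 ug/mL, with a likely range from 3.5 ug/mL to 14 ug/mL.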

Compound 4, half-maximal inhibitory concentration: 2.87 ug/mL
Compound 4: the middle estimate sits 2.4-fold (0.39 log units) above what was measured, and the stated range ends above it.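

In this assay, replacing the 4-chlorophenyl group with 4-bromophenyl gave a 2.4-fold lower number from compound 3 to compound 4 (0.37 log units; beyond the scatter), and set beside the earlier exchange of chloro for bromo, the two steps do not agree: the same change on two cores in this assay, a 1.3-fold higher number (0.10 log units; within the scatter) from compound 2 to compound 1 and a 2.4-fold lower number (0.37 log units; beyond the scatter) from compound 3 to compound 4, 3.0-fold (0.48 log units) apart, beyond the scatter of two such steps

This shows that, in this series, the exchange of chloro for bromo cannot be carried from one core to another as a step of fixed size, since the same kind of change left the number as good as unchanged on one core and lowered it on the other. For the compounds shown here, it does not show what sets the two steps apart, as the two pairs differ both in their cores and in where the exchanged halogen sits, and only two such steps are available, too few to give a rule for any further core.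

On these data alone, the halogens exchanged here are only chloro and bromo, so it remains open how fluoro, an amine or a carboxylic acid in the place of the 4-chlorophenyl group's chloro would compare. Also open, as far as these compounds go, is whether the exchange on a further core would follow the step seen with compound 1 and compound 2, the step seen with compound 3 and compound 4, or neither.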